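Carbonyl-carbon substituent: from compound 2 to compound 3

This account rests on a few compounds, and the source may have more. Where it says the series, first, only, none or still open, it means among the compounds named here.

Two compounds in the series have numbers in a functional assay on isolated protein for inhibition of Glucose-dependent insulinotropic receptor (Homo sapiens), read by HTRF and cAMP accumulation; a lower number here means that less compound is needed, a higher number that more compound is needed for the effect. Compound 1 `Cc1nc(S(C)(=O)=O)ccc1Oc1ncnc(OC2CCN(C(=O)O[C@@H](C)C(F)(F)F)CC2)c1F` gives 9.86 nM, and compound 2 `CCC(F)(F)C(=O)N1CCC(Oc2ncnc(Oc3ccc(S(C)(=O)=O)nc3C)c2F)CC1` gives 17.4 nM. Within the data shown here, compound 2 holds the higher of the two numbers, with compound 1 as its only neighbour, and the one measured step between them, a 1.8-fold higher number from compound 1 to compound 2 (0.25 log units; within the scatter), lies within the scatter, so the two cannot be ordered.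

Compound 3 `Cc1nc(S(C)(=O)=O)ccc1Oc1ncnc(OC2CCN(C(=O)c3noc(C(C)C)n3)CC2)c1F` has not yet been measured in this assay. It differs from compound 2 in one place: 5-isopropyl-1,2,4-oxadiazol-3-yl in place of 1,1-difluoropropyl on a carbonyl carbon.

Among the measured compounds shown here, the only measured step that bears on this change is the one at the same carbonyl carbon, a 1.8-fold higher number from compound 1 to compound 2 (0.25 log units; within the scatter), which exchanged one group on that carbon for another and stayed within the scatter. For the measured compounds named here, the present change is of a different kind, bringing in a five-membered aromatic ring where 1,1-difluoropropyl stood, and no measured step covers such a swap. The expectation is therefore no step beyond the scatter, with wider uncertainty than the measured step suggests, so a 1.2-fold lower number from compound 2 to compound 3 (0.06 log units; within the scatter) is the expected step. Compound 3 is estimated at 15 nM, with a range of 4 nM to 60 nM.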

Compound 3, half-maximal effective concentration: 21.2 nM
For compound 3 the middle estimate is 1.4-fold (0.15 log units) below the measured one; the measured number falls inside the stated range.
By their numbers in this assay, from the lowest: compounds 1, 2 and 3 (each within the scatter of the next, the first and the last beyond it).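

At the carbonyl carbon on the amide-type nitrogen in a ring, this assay accommodates an aromatic group: 5-isopropyl-1,2,4-oxadiazol-3-yl in place of 1,1-difluoropropyl gives a 1.2-fold higher number from compound 2 to compound 3 (0.09 log units; within the scatter) even though the entering group has more heavy atoms, a five-membered aromatic ring with 3 hetero atoms and 3 hydrogen-bond acceptors, where the leaving group has no ring and no acceptors. Set against 1-(trifluoromethyl)ethoxy, the same heterocycle gives a 2.2-fold higher number from compound 1 to compound 3 (0.33 log units; beyond the scatter) and so provides the first step at this position beyond the scatter, although a modest one, while the two steps that involve 1,1-difluoropropyl each remain within the scatter. Nothing available accounts for either step.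

The compounds shown leave open whether this carbonyl carbon would accept an amine, a phenyl ring or a longer alkyl chain, and whether the isopropyl group on the heterocycle matters compared with a methyl group. Also open, on these data alone, is whether these three carbonyl substituents would keep the same order if the shared core were changed elsewhere.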